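The source may hold more compounds than are shown below. What is called first, only, known or untested is meant among the compounds shown, and "the series" means these compounds.

Measured so far:
compound 1 `C[C@@H](O[C@@H]1CN(C(=O)C(C)(C)C)C[C@H]1c1ccccc1)c1cc(C(F)(F)F)cc(C(F)(F)F)c1` — 0.18 nM
compound 2 `C[C@@H](O[C@@H]1CN(C(=O)[C@@H]2CCC(=O)N2C)C[C@H]1c1ccc(F)cc1)c1cc(C(F)(F)F)cc(C(F)(F)F)c1` — 0.12 nM
compound 3 `C[C@@H](O[C@@H]1CN(C(=O)N2CCOCC2)C[C@H]1c1ccccc1)c1cc(C(F)(F)F)cc(C(F)(F)F)c1` — 0.16 nM

All three numbers come from an assay on CHO cells for displacement of a labelled ligand from Substance-P receptor (Homo sapiens); a lower number here means a stronger inhibitor, a higher number a weaker inhibitor. Compound 2 sits within the usual scatter of both compound 1 and compound 3, so the three cannot be told apart on these data. Compound 4 `CCNC(=O)N1C[C@@H](O[C@H](C)c2cc(C(F)(F)F)cc(C(F)(F)F)c2)[C@H](c2ccc(F)cc2)C1` is not yet measured; it differs from compound 2 in one place: ethylamino in place of 1-methyl-5-oxopyrrolidin-2-yl on a carbonyl carbon. Going by the values given here, the only measured step at the same carbonyl carbon is a 1.1-fold lower number from compound 1 to compound 3 (0.05 log units; within the scatter), a swap of one group on that carbon that stayed within the scatter. On that basis the exchange in compound 4 is expected to move the number little, if at all, with a 1.3-fold higher number from compound 2 to compound 4 (0.10 log units; within the scatter) as the expected step. Compound 4 is therefore estimated at 0.15 nM, with a range from 0.06 nM to 0.4 nM.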

Compound 4, half-maximal inhibitory concentration: 0.1 nM
For compound 4 the middle estimate is 1.5-fold (0.18 log units) above the measured one; low and high end bracket the measured number.
By their numbers in this assay, from the lowest: compounds 4, 2, 3 and 1 (each within the scatter of the next).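

In this assay, putting ethylamino in place of 1-methyl-5-oxopyrrolidin-2-yl on this carbonyl carbon gives a 1.2-fold lower number from compound 2 to compound 4 (0.08 log units; within the scatter). This place therefore accepts a smaller group with no ring and no defined stereocentre, and one with a hydrogen-bond donor, without a change that can be read from the scatter. No measurement shown here offers an explanation for this. On these data alone, it remains open whether a carboxylic acid, a primary amine or a chain much longer than ethyl on the same carbonyl carbon would also leave the number in place.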